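A few compounds are considered here, and "the series" means these few. Any claim that something is new, unique, unknown or untested is made for them only; others in the source may bear on it.

Three compounds of this series have numbers in a functional assay on L1210 cells (Mus musculus) for inhibition, read by cell counting, with a stated time of 2 days; on this read-out lower numbers stand for stronger inhibition and higher numbers for weaker inhibition. Compound 1 `C=C(Br)C(=O)Nc1cccc(-c2cn3nc(-c4ccc(CC)cc4)sc3n2)c1` gives 2200 nM in this assay, which is the second highest of the three numbers. Compound 3 `C=C(Br)C(=O)Nc1cccc(-c2cn3c(-c4ccc(OC)cc4)csc3n2)c1` gives 200 nM, a lower number that lies beyond the scatter, and compound 2 `COc1ccc(Cc2nn3cc(-c4cccc(N)c4)nc3s2)cc1` gives 227000 nM, a much higher number that also lies beyond the scatter. Compound 3 differs from compound 1 in more than one place, so its lower number cannot be laid at any single change, and compound 2 differs from compound 1 in still more ways.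

Compound 4 `C=C(Br)C(=O)Nc1cccc(-c2cn3nc(-c4ccc(OC)cc4)sc3n2)c1` has not yet been measured. It differs from compound 1 in one place: methoxy in place of ethyl on an aromatic carbon. For the measured compounds named here, no pair of measured compounds separated only by this change exists in the set, so there is no direct step to lean on. Compound 3 also carries a 4-methoxyphenyl group, on a differently arranged core, and gives 200 nM, which points gently toward a lower number for compound 4. Compound 4 is therefore expected to give 1200 nM in this assay, within a range from 400 nM to 4000 nM. The step expected from compound 1 to compound 4 is a 1.8-fold lower number from compound 1 to compound 4 (0.26 log units; within the scatter), a modest move that may not clear the scatter.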

Compound 4, half-maximal inhibitory concentration: 940 nM
Estimate against measurement, compound 4: 1.3-fold (0.11 log units) above; low and high end bracket the measured number.
By their numbers in this assay, from the lowest: compound 3; then compound 4; then compound 1; then compound 2.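

In this assay, for the compounds shown here, putting 4-methoxyphenyl in place of 4-ethylphenyl on the shared core gives a 2.3-fold lower number from compound 1 to compound 4 (0.37 log units; beyond the scatter), the first comparison in which only one place changes. Going by these compounds alone, the step is modest, yet it lies beyond the scatter, so the group on this aromatic carbon, para to a large group, does bear on the number, which the earlier compounds could not show because each differed from compound 1 in more than one place. No measurement at hand says what about methoxy goes with the lower number, and swapping two heavy atoms for two others of which one is oxygen describes the change without explaining it.

The compounds shown leave open how a hydroxyl group, an amine or a longer chain such as propyl on this same aromatic carbon would read in this assay. They also leave open whether the same change would give a similar step on the core of compound 3, as this single pair is one observation and not a pattern.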